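The source may report more compounds than this note shows. Statements on the series, on what has been measured and on what is new or still open speak of the compounds shown alone.

Working notes on the series. In a functional assay on A549 cells (Homo sapiens) for inhibition, read by MTT assay, with a stated time of 48 h (on this read-out higher numbers stand for weaker inhibition and lower numbers for stronger inhibition), compound 1 `CCCCN1CCn2nc(-c3ccccc3)cc2C1=O` gives only the assay limit, > 64000 nM. Compound 2 `COc1ccc(-c2cc3n(n2)CCN(Cc2ccc(Cl)nc2)C3=O)cc1` likewise gives only a limit in this assay, > 64000 nM. Compound 3 `COc1ccc(-c2cc3n(n2)CCN(C(C)C)C3=O)cc1` also reaches only the limit in this assay, > 64000 nM. Among the measured compounds shown here, the one single-point step so far, a step that the two limits leave unreadable from compound 2 to compound 3, is therefore not readable in size. Compound 3 thus stands at the common limit of > 64000 nM in this assay, at which 3 of the 3 values shown sit, together with every other measured member, with no numerical value of its own.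

Compound 4 `CCCCN1CCn2nc(-c3ccc(OC)cc3)cc2C1=O` differs from compound 3 in one place: butyl in place of isopropyl on an amide-type nitrogen in a ring. For the measured compounds named here, no measured step bears directly on this exchange. Going by the values given here, the only measured step, from compound 2 to compound 3, is itself unreadable. Compound 1, which carries the same butyl group on the same ring nitrogen, gave no number in this assay either. Nothing here points to a gain in inhibition. Compound 4 is therefore expected to give only a limit again, an estimated 100000 nM with a range from 40000 nM to 300000 nM. The expected step that the limit leaves unreadable from compound 3 to compound 4 is accordingly taken as none beyond the scatter.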

Compound 4, half-maximal inhibitory concentration: 62500 nM
Compound 4: the middle estimate sits 1.6-fold (0.20 log units) above what was measured; measured number inside the range.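

In this assay, among the compounds shown here, compound 4 is the first member to give a number rather than a limit, 62500 nM. Its steps can be read only as floors: butyl in place of isopropyl on the amide-type nitrogen in a ring gives an at least 1.0-fold lower number from compound 3 to compound 4 (0.01 log units; that floor lies within the scatter), methoxy in place of hydrogen on an aromatic carbon gives an at least 1.0-fold lower number from compound 1 to compound 4 (0.01 log units; that floor lies within the scatter), and propyl in place of 6-chloropyridin-3-yl on a saturated chain carbon bound to that nitrogen gives an at least 1.0-fold lower number from compound 2 to compound 4 (0.01 log units; that floor lies within the scatter), so none shows a change beyond the scatter. The other members give no number, only a limit of the assay: the limit of > 64000 nM in this assay, at which 3 of the 4 values shown sit.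

As far as these compounds go, whether butyl or methoxy matters at either place therefore stays open. A hexyl chain or a chain ending in an amine on the amide-type nitrogen in a ring remains untested among the compounds shown.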